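Chalcone-type series: aryl ketone swap on the pyridyl scaffold

A few compounds are considered here, and "the series" means these few. Any claim that something is new, unique, unknown or untested is made for them only; others in the source may bear on it.

Three compounds of the series carry a measured number. Compound 1 `COc1ccc(OC)c(C(=O)/C=C/c2cn(-c3ccccc3)nc2-c2ccsc2)c1` gives 400 nM in a functional assay on MCF7 cells (Homo sapiens) for inhibition, read by sulforhodamine B assay, with a stated time of 72 h; on this read-out lower numbers stand for stronger inhibition and higher numbers for weaker inhibition. Compound 2 `O=C(/C=C/c1cn(-c2ccccc2)nc1-c1cccnc1)c1cc[nH]c1` gives 6900 nM in this assay, and compound 3 `COc1cc(C(=O)/C=C/c2cn(-c3ccccc3)nc2-c2cccnc2)cc(OC)c1OC` gives 14500 nM. Compound 2 thus stands second highest of the three numbers; its gap to compound 3 lies just beyond the scatter, and its gap to compound 1 is wide and well beyond it. Within the data shown here, no pair of these three differs in only one place, so no single-point step can be read off directly.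

Compound 4 `COc1ccc(C(=O)/C=C/c2cn(-c3ccccc3)nc2-c2cccnc2)c(OC)c1` is not yet measured. It departs from compound 2 by one change: 2,4-dimethoxyphenyl in place of 1H-pyrrol-3-yl on a carbonyl carbon. Compound 1, which also carries a dimethoxyphenyl on the carbonyl carbon, gives 400 nM. Compound 3 carries the same pyridyl as compound 2 but a trimethoxyphenyl on that carbon, and compound 3 gives 14500 nM; the two pointers disagree. For compound 4 a moderate step downward is expected, a 2.3-fold lower number from compound 2 to compound 4 (0.36 log units; beyond the scatter), around the edge of the scatter. The estimated value for compound 4 is 3000 nM, with a range from 800 nM to 12000 nM.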

Compound 4, half-maximal inhibitory concentration: 2300 nM
Compound 4: middle estimate off by 1.3-fold (0.12 log units), on the high side; the measured number falls inside the stated range.
By their numbers in this assay, from the lowest: compound 1; then compound 4; then compound 2; then compound 3.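

Among these compounds, the first single-point step falls on a carbonyl carbon: in this assay, 2,4-dimethoxyphenyl in place of 1H-pyrrol-3-yl gives a 3.0-fold lower number from compound 2 to compound 4 (0.48 log units; beyond the scatter), a modest change. At this position, the hydrogen-bond donor of the 1H-pyrrol-3-yl is therefore not needed to keep the number from rising, and the larger six-membered aromatic ring of carbon only is accepted. No measurement on hand explains the direction or size of this step.

Among the compounds shown here, the single step changes the ring and adds both methoxy groups at once, so their separate contributions stay unresolved. Also open, from the compounds shown here alone, is how the number would move with plain phenyl, or with a phenyl carrying an amine or a carboxylic acid, on the same carbonyl carbon.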